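The source may hold more compounds than are shown below. What is called first, only, known or untested is meant among the compounds shown, and "the series" means these compounds.

Of the compounds shown here, three have so far been tested in an assay on microsomes for inhibition of Amine oxidase [flavin-containing] A (Homo sapiens), read by fluorescence and spectrophotometry, with a stated time of 20 min; a lower number here means a stronger inhibitor, a higher number a weaker inhibitor. Compound 1 `N#Cc1ccc(Sc2ccc(Br)cc2)cc1C#N` gives 19000 nM, the second highest of the three numbers. Compound 2 `N#Cc1ccc(SC2CCCC2)cc1C#N` gives 2780 nM, a clearly lower number, while compound 3 `N#Cc1ccc(SCc2ccc(F)cc2)cc1` gives 54700 nM, the highest of the three. Compound 4 `N#Cc1ccc(Sc2ccc(Br)cc2)cc1` has not yet been measured in this assay. Going from compound 1 to compound 4, the change is hydrogen in place of cyano on an aromatic carbon. Among the measured compounds shown here, no pair of measured compounds shows this change on its own; compound 3, which also carries only one cyano on its core, has the highest number of the three. The expected step is a moderate move toward a higher number, beyond the scatter, estimated as a 2.1-fold higher number from compound 1 to compound 4 (0.32 log units; beyond the scatter). Compound 4 is therefore expected to give 40000 nM, within a range from 12000 nM to 130000 nM.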

Compound 4, half-maximal inhibitory concentration: 8520 nM
Beside the measured number, compound 4's estimate is 4.7-fold (0.67 log units) above it; the whole stated range lies above it.
By their numbers in this assay, from the lowest: compound 2; then compound 4; then compound 1; then compound 3.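

In this assay the swap of hydrogen for cyano on this aromatic carbon gives a 2.2-fold lower number from compound 1 to compound 4 (0.35 log units; beyond the scatter) and so a modest gain in inhibition, not a loss. The cyano group removed here is therefore not required for inhibition in this pair of compounds. Among the compounds shown here, nothing measured so far explains the step. Going by these compounds, whether the same swap would act alike in compound 2 remains open. Also open, on these data alone, is how an amine or a methoxy group on this carbon would compare with hydrogen and cyano.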